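Carboxy in Place of Propyl at the End of a Thioether Chain

A few compounds are considered here, and "the series" means these few. Any claim that something is new, unique, unknown or untested is made for them only; others in the source may bear on it.

Measured so far in an in vitro functional assay on 1321-N1 cells for agonist activity at P2Y purinoceptor 6 (Homo sapiens); on this read-out lower numbers stand for an effect already at smaller amounts and higher numbers for an effect only at larger amounts of compound:
Compound 1 `O=c1[nH]c(=S)ccn1[C@@H]1O[C@H](COP(=O)(O)OP(=O)(O)O)[C@@H](O)[C@H]1O` gives 80 nM.
Compound 2 `O=c1nc(SCc2ccccc2)ccn1[C@@H]1O[C@H](COP(=O)(O)OP(=O)(O)O)[C@@H](O)[C@H]1O` gives 800 nM.
Compound 3 `CCCCCCSc1ccn([C@@H]2O[C@H](COP(=O)(O)OP(=O)(O)O)[C@@H](O)[C@H]2O)c(=O)n1` gives 4900 nM.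

Compound 3 stands at the highest number of the three, beyond the scatter from both others. Within the data shown here, the only single-place step recorded, a 6.1-fold higher number from compound 2 to compound 3 (0.79 log units; beyond the scatter), shows that a change at the chain bound to the sulfur can shift the result noticeably.

Compound 4 `O=C(O)CCCSc1ccn([C@@H]2O[C@H](COP(=O)(O)OP(=O)(O)O)[C@@H](O)[C@H]2O)c(=O)n1` differs from compound 3 by carboxy in place of propyl on a saturated chain carbon, three bonds along the chain from a sulfur. Among the measured compounds shown here, no measured pair swaps a chain end for a carboxy, so that step offers no direct guide to the direction. With nothing to push the expectation either way, compound 4 is expected to stay near compound 3, a 1.4-fold lower number from compound 3 to compound 4 (0.15 log units; within the scatter), within the scatter but with a broad range. The estimate for compound 4 is 3500 nM, expected to fall between 600 nM and 20000 nM.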

Compound 4, half-maximal effective concentration: 8800 nM
Compound 4: middle estimate off by 2.5-fold (0.40 log units), on the low side; measured number inside the range.
By their numbers in this assay, from the lowest: compound 1; then compound 2; then compounds 3 and 4 (each within the scatter of the next).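

In this assay the swap of carboxy for propyl, three bonds along the chain from a sulfur, gives a 1.8-fold higher number from compound 3 to compound 4 (0.25 log units; within the scatter) and so shows that a carboxy at this chain end cannot be told apart from the all-carbon end. Putting 2-carboxyethyl in place of phenyl on the saturated chain carbon bound to a sulfur gives an 11-fold higher number from compound 2 to compound 4 (1.04 log units; beyond the scatter) and so shows that the phenyl end differs clearly from this carboxy end. Nothing available explains either result.

As far as these compounds go, whether an amine or an ester at this chain end would give a lower number remains open.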